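Dropping the trifluoromethyl from the weakest compound

A few compounds are considered here, and "the series" means these few. Any claim that something is new, unique, unknown or untested is made for them only; others in the source may bear on it.

Compound 2, with the structure `CCC(C(=O)N1CCN(c2ccc(C(F)(F)F)cc2)CC1)N1C(=O)CCC1=O`, was tested in a functional assay on the whole organism (strain Swiss) with Mus musculus as the target, in the maximal electroshock model, with a stated time of 0.5 h, at a dose of 300 mg/kg by the intraperitoneal route (a higher number here means a stronger effect of the compound at the dose given, a lower number a weaker effect), and there compound 2 gives 0%. That is the lowest of the three numbers measured. Its nearest neighbour is compound 1, `CC(C(=O)N1CCN(c2ccc(C(F)(F)F)cc2)CC1)N1C(=O)CCC1=O`, which differs only by a methyl in place of hydrogen on a saturated chain carbon; compound 1 gives 25%, and the step of a number 25 percentage points lower from compound 1 to compound 2 (beyond the scatter) lost a modest amount. Furthest away is compound 3, `CC(C(=O)N1CCN(c2cccc(Cl)c2)CC1)N1C(=O)CCC1=O`, which gives 100%; it differs from compound 1 in more than one place, so its two values with compound 1 can only be read side by side.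

The next compound, compound 4, has the structure `CCC(C(=O)N1CCN(c2ccccc2)CC1)N1C(=O)CCC1=O`. Compared with compound 2 the change is hydrogen in place of trifluoromethyl on an aromatic carbon. For the measured compounds named here, no measured step touches the six-membered aromatic ring of carbon only; the only step recorded concerns the chain, so its size says nothing about this change. What compound 1 and compound 3 show together is that groups on this ring can move the number strongly, yet without telling the direction for a trifluoromethyl alone.

Because compound 2 sits at 0%, the expected step of a number 15 percentage points higher from compound 2 to compound 4 (beyond the scatter) can only go up or stay within the scatter. The estimate for compound 4 is 15%, with a range from 0% to 55%.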

Compound 4, a percentage reported as activity, at one dose (the size of the read-out at that dose, not a potency): 75%
For compound 4 the middle estimate is 60 percentage points below the measured one, and the stated range ends below it.
By their numbers in this assay, from the lowest: compound 2; then compound 1; then compound 4; then compound 3.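

In this assay, for the compounds shown here, the step of a number 75 percentage points higher from compound 2 to compound 4 (beyond the scatter) is the first reading of a single change on the six-membered aromatic ring, as every earlier single-place comparison concerned only the chain. It shows that this position, para to a large group, is not a neutral spot in this series: with the rest of compound 2 held constant, trifluoromethyl and hydrogen give clearly different read-outs at the dose tested. It also shows that a compound with the longer chain of compound 2 can still give a strong read-out.

The compounds shown leave open whether other groups at this position, such as a methoxy group or a single fluorine atom, would behave more like hydrogen or more like trifluoromethyl, and whether removing trifluoromethyl from compound 1 would produce a step of similar size. No measurement in hand speaks to what lies behind the size of this step.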